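Trifluoromethyl in place of fluoro on the aromatic ring

The compounds below may be only part of what the source reports. "The series", "measured", "known", "first", "only" and "open" are said of these compounds alone.

Three compounds share one core and differ only in a single group on a six-membered aromatic ring of carbon only. Compound 1 `Nc1n[nH]c2cc(-c3ccc(=O)n(Cc4cccc(Cl)c4)c3)ccc12` gives 6 nM in an assay for inhibition of MAP kinase-interacting serine/threonine-protein kinase 2 (Homo sapiens), read by luminescence and ADP-Glo, with a stated time of 2 h; a lower number here means a stronger inhibitor, a higher number a weaker inhibitor. Compound 2 `CC(=O)Nc1cccc(Cn2cc(-c3ccc4c(N)n[nH]c4c3)ccc2=O)c1` gives 8 nM, and compound 3 `Nc1n[nH]c2cc(-c3ccc(=O)n(Cc4cccc(F)c4)c3)ccc12` gives 5 nM, which stands at the low end of the three numbers, though its steps to both others, a 1.2-fold lower number from compound 1 to compound 3 (0.08 log units; within the scatter) and a 1.6-fold lower number from compound 2 to compound 3 (0.20 log units; within the scatter), stay within the scatter, as does a 1.3-fold higher number from compound 1 to compound 2 (0.12 log units; within the scatter). Compound 4 `Nc1n[nH]c2cc(-c3ccc(=O)n(Cc4cccc(C(F)(F)F)c4)c3)ccc12` carries trifluoromethyl in place of fluoro on an aromatic carbon. For the measured compounds named here, no measured step tests trifluoromethyl itself; the changes seen at this position, from one halogen to another and to acetamido, moved the number little, so the expectation for compound 4 is a step of a 1.2-fold higher number from compound 3 to compound 4 (0.08 log units; within the scatter), within the scatter. Compound 4 is therefore estimated at 6 nM, with a range from 3 nM to 15 nM.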

Compound 4, half-maximal inhibitory concentration: 21 nM
For compound 4 the middle estimate is 3.5-fold (0.54 log units) below the measured one; the whole stated range lies below it.
By their numbers in this assay, from the lowest: compounds 3, 1 and 2 (each within the scatter of the next); then compound 4.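

Trifluoromethyl is the first group at this position to move the number beyond the scatter in this assay, with a 4.2-fold higher number from compound 3 to compound 4 (0.62 log units; beyond the scatter), a 3.5-fold higher number from compound 1 to compound 4 (0.54 log units; beyond the scatter) and a 2.6-fold higher number from compound 2 to compound 4 (0.42 log units; beyond the scatter). The position therefore does not accept every group equally, and the change is not simply a matter of replacing a halogen, since acetamido stays within the scatter of chloro and fluoro. Nothing measured here gives a reason for this step. On these data alone, whether methyl, methoxy or nitrile at this position would follow trifluoromethyl or the three earlier groups remains open.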